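Para-bromo to meta-methyl on the amide of compound 3

The compounds below may be only part of what the source reports. "The series", "measured", "known", "first", "only" and "open" are said of these compounds alone.

Compound 2 `O=C(Nc1cccc(-c2oc3cc(-c4ccc(F)cc4)ccc3c(=O)c2O)c1)c1ccc(Br)cc1` carries the highest of the two numbers recorded in a functional assay on MDA-MB-231 cells (Homo sapiens) for antiproliferative activity, read by CCK-8 assay, with a stated time of 72 h (a lower number here means a stronger inhibitor, a higher number a weaker inhibitor), where compound 2 gives 24900 nM; its nearest neighbour is compound 1 `O=C(Nc1cccc(-c2oc3cc(-c4ccc(F)cc4)ccc3c(=O)c2O)c1)c1ccc(Cl)cc1`, which gives 12800 nM. Compound 3 `Cc1cccc(C(=O)Nc2cccc(-c3oc4cc(-c5ccc(F)cc5)ccc4c(=O)c3O)c2)c1` differs from compound 2 by 3-methylphenyl in place of 4-bromophenyl on a carbonyl carbon. Among the measured compounds shown here, the only measured step, a 1.9-fold higher number from compound 1 to compound 2 (0.29 log units; within the scatter), concerns a para-halogen exchange and stays within the scatter, so no step in this assay beyond the scatter is expected for compound 3, giving an estimated 1.6-fold lower number from compound 2 to compound 3 (0.19 log units; within the scatter). Compound 3 is therefore expected to give about 16000 nM, within 5000 nM to 50000 nM.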

Compound 3, half-maximal inhibitory concentration: 2840 nM
Estimate against measurement, compound 3: 5.6-fold (0.75 log units) above, outside the stated range (below it).
By their numbers in this assay, from the lowest: compound 3; then compounds 1 and 2 (each within the scatter of the next).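

On the carbonyl carbon, the aryl group can shift the number in this assay beyond the scatter, which the chloro-to-bromo exchange alone did not show: 3-methylphenyl in place of 4-bromophenyl gives an 8.8-fold lower number from compound 2 to compound 3 (0.94 log units; beyond the scatter), and 3-methylphenyl in place of 4-chlorophenyl gives a 4.5-fold lower number from compound 1 to compound 3 (0.65 log units; beyond the scatter). No evidence is available on what lies behind this shift.

Compound 3 changes both the substituent and its printed ring position, so the contribution of each remains unresolved. The compounds shown also leave open how a 4-methylphenyl group, a methoxy group or an amine would read here.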